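From Cyclopropyl to Ethyl on an Aromatic Nitrogen

This account rests on a few compounds, and the source may have more. Where it says the series, first, only, none or still open, it means among the compounds named here.

Of the compounds shown here, two have been measured in a functional assay on HL-60 cells (Homo sapiens) for antiproliferative activity, read by MTT assay, with a stated time of 72 h; on this read-out higher numbers stand for weaker inhibition and lower numbers for stronger inhibition. There, compound 1 `CCn1cc(C(=O)O)c(=O)c2cc(F)c(N3CCN(C(=N)NS(=O)(=O)c4ccccc4Cl)CC3)cc21` gives 43 nM. Compound 2 `N=C(NS(=O)(=O)c1ccccc1C(F)(F)F)N1CCN(c2cc3c(cc2F)c(=O)c(C(=O)O)cn3C2CC2)CC1` gives 43 nM, which places compound 2 level with compound 1, with no difference beyond the scatter. Compound 3 `CCn1cc(C(=O)O)c(=O)c2cc(F)c(N3CCN(C(=N)NS(=O)(=O)c4ccccc4C(F)(F)F)CC3)cc21` remains unmeasured in this assay. Its structure departs from that of compound 2 in one place, with ethyl in place of cyclopropyl on an aromatic nitrogen. Going by the values given here, no measured pair shows this change alone, so any forecast is uncertain. No step beyond the scatter is expected in this assay. That expectation rests on compound 1, which also carries ethyl on an aromatic nitrogen and gives 43 nM. The expected change is small, a 1.0-fold higher number from compound 2 to compound 3 (0.02 log units; within the scatter). For compound 3 the estimated value is 45 nM, with an expected range of 18 nM to 110 nM.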

Compound 3, half-maximal inhibitory concentration: 43 nM
Compound 3: middle estimate off by 1.0-fold (0.02 log units), on the high side, within the range that was stated.
By their numbers in this assay, from the lowest: compounds 1, 2 and 3 (each within the scatter of the next).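

In this assay the change from cyclopropyl to ethyl on the aromatic nitrogen can now be read directly, with trifluoromethyl held constant on the aromatic carbon, and it gives no change at the digits printed from compound 2 to compound 3 (within the scatter). With ethyl held on that nitrogen, trifluoromethyl in place of chloro on an aromatic carbon gives no change at the digits printed from compound 1 to compound 3 (within the scatter), so this position and the aromatic carbon have each now been read through a single change, and neither step leaves the scatter. Nothing available here offers an explanation for these two results.

At the aromatic nitrogen, the compounds shown cover only ethyl and cyclopropyl, so it remains open how a longer chain such as n-butyl or a benzyl group would read there. From the compounds shown here alone, on the aromatic carbon, the effect of an amine or a methoxy group in place of chloro or trifluoromethyl also remains open.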